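The source may report more compounds than this note shows. Statements on the series, on what has been measured and on what is new or still open speak of the compounds shown alone.

Compound 1, whose structure is `CCN1CCCC1CNC(=O)c1cc(N(C)S(=O)(=O)N(C)C)ccc1OC`, was tested in a functional assay on the whole organism for inhibition, with Mus musculus as the target (a higher number here means that more compound is needed for the effect, a lower number that less compound is needed), where compound 1 gives 36.2 mg/kg. Compound 2, `CCN1CCCC1CNC(=O)c1cc(N(C)S(=O)(=O)N(C)C)c(C)cc1OC`, carries a single change on the shared core: methyl in place of hydrogen on an aromatic carbon. In this assay compound 2 reaches only the limit of the measurement, > 50 mg/kg. The step that this change made is an at least 1.3-fold higher number from compound 1 to compound 2 (0.14 log units; that floor lies within the scatter). Compound 3, `CCN1CCCC1CNC(=O)c1cc(NS(N)(=O)=O)ccc1OC`, differs from compound 1 in another way: sulfamoylamino in place of (dimethylsulfamoyl)(methyl)amino on an aromatic carbon. For compound 3 this assay likewise records only a limit, > 50 mg/kg. That step is an at least 1.3-fold higher number from compound 1 to compound 3 (0.14 log units; that floor lies within the scatter). Two of the three values shown therefore sit at the limit of > 50 mg/kg in this assay, at which 2 of the 3 values shown sit, so both steps from compound 1 are known only as floors, and those floors lie within the usual scatter of the assay.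

Compound 4, `CCN1CCCC1CNC(=O)c1cc(NS(N)(=O)=O)c(C)cc1OC`, has not been measured. It differs from compound 3 by methyl in place of hydrogen on an aromatic carbon. This is the same kind of change as that from compound 1 to compound 2, but the surroundings differ: in compound 4 the methyl enters ortho to a sulfamoylamino group, while in compound 2 it entered ortho to a (dimethylsulfamoyl)(methyl)amino group. Since compound 3 already stands at a limit with > 50 mg/kg, and the earlier step of an at least 1.3-fold higher number from compound 1 to compound 2 (0.14 log units; that floor lies within the scatter) gave no sign of a lower number, the step from compound 3 to compound 4 is expected to be a step that the limit leaves unreadable from compound 3 to compound 4. Compound 4 is thus estimated at 90 mg/kg in this assay, with a range from 40 mg/kg to 250 mg/kg, and most likely only a limit would be reported.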

Compound 4, dose for half-maximal effect: > 50 mg/kg
Compound 4: a limit, no number; the forecaster's own chance of this, stated with the estimate: 85%; the middle value does not contradict the limit.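

In this assay compound 4 gives > 50 mg/kg, which is a limit and not a number. The steps from compound 3 and from compound 2 to compound 4 therefore cannot be read, as each joins two limits: the limit of > 50 mg/kg in this assay, at which 3 of the 4 values shown sit. The compounds shown leave open how compound 2, compound 3 and compound 4 compare, and whether either change alters the number at all.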